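The source may hold more compounds than are shown below. What is called first, only, known or untested is meant among the compounds shown, and "the series" means these compounds.

Compound 1 `COc1ccccc1-c1ccc2ncn(-c3cc(OC)c(OC)c(OC)c3)c2c1` is the starting point. In a functional assay on SGC-7901 cells (Homo sapiens) for antiproliferative activity, read by MTT assay, with a stated time of 72 h (a higher number here means a weaker inhibitor, a lower number a stronger inhibitor), compound 1 gives 5050 nM. Among the values shown for this assay, this is the only plain number; the other value is a limit. Compound 2 `COc1cc(-n2cnc3ccc(-c4ccccc4Cl)cc32)cc(OC)c1OC` in this assay reaches only > 10000 nM, which is a limit of the assay and not a number. It sits at the limit of > 10000 nM in this assay, at which 1 of the 2 values shown sits. Accordingly the step of an at least 1.9-fold higher number from compound 1 to compound 2 (0.29 log units; that floor lies within the scatter) gives only a floor, and that floor lies within the scatter.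

Compound 3 `COc1cc(-n2cnc3ccc(-c4ccc([N+](=O)[O-])cc4)cc32)cc(OC)c1OC` has not yet been measured in this assay. It differs from compound 1 in one place: 4-nitrophenyl in place of 2-methoxyphenyl on an aromatic carbon. For the measured compounds named here, the single measured step, an at least 1.9-fold higher number from compound 1 to compound 2 (0.29 log units; that floor lies within the scatter), bears on this change only loosely, since it also swaps the group at the same place on the shared core, and its floor stayed within the scatter. Going by the values given here, no measured step shows how a 4-nitrophenyl behaves here. Compound 3 is therefore expected to give 8000 nM, with a range from 3000 nM to 20000 nM. The expected step of a 1.6-fold higher number from compound 1 to compound 3 (0.20 log units; within the scatter) points toward a weaker inhibitor, with a real chance that only a limit is reported.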

Compound 3, half-maximal inhibitory concentration: 79 nM
Beside the measured number, compound 3's estimate is 100-fold (2.01 log units) above it; the whole stated range lies above it.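

In this assay, for the compounds shown here, putting 4-nitrophenyl in place of 2-methoxyphenyl on this aromatic carbon gives a 64-fold lower number from compound 1 to compound 3 (1.81 log units; beyond the scatter), so activity here depends strongly on which substituted phenyl the shared core carries, something the one earlier step could not show with its floor inside the scatter. Putting 4-nitrophenyl in place of 2-chlorophenyl gives an at least 120-fold lower number from compound 2 to compound 3 (2.10 log units; beyond the scatter), and the size of that step is only a floor. The value of compound 2 is a limit and not a number: the limit of > 10000 nM in this assay, at which 1 of the 3 values shown sits.

The compounds shown leave open whether the gain belongs to the nitro group itself or to where it sits on the phenyl ring, as the names 2-methoxyphenyl, 2-chlorophenyl and 4-nitrophenyl show that the substituent and its place change together in these steps. On these data alone, how a plain phenyl, or a phenyl ring bearing an amine or a carboxylic acid, would compare on this carbon also stays open, and so does whether the result extends beyond this one cell line.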